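A few compounds are considered here, and "the series" means these few. Any claim that something is new, unique, unknown or untested is made for them only; others in the source may bear on it.

Of the compounds shown here, three sharing one core have been measured in a physicochemical assay for solubility, measured as kinetic solubility, at pH 7.4; a lower number here means a less soluble compound, a higher number a more soluble compound. Compound 1 `COc1cc(N2CCNCC2)ccc1Nc1nc(NC2CCCCC2)c2nc[nH]c2n1`, which has a hydrogen on an amine nitrogen in a ring, gives 19000 nM. Compound 2 `COc1cc(N2CCN(C(=O)C3CCC(O)CC3)CC2)ccc1Nc1nc(NC2CCCCC2)c2nc[nH]c2n1` gives 19000 nM, and placing (4-hydroxycyclohexyl)carbonyl on that nitrogen makes no change at the digits printed from compound 1 to compound 2 (within the scatter). Compound 3 `COc1cc(N2CCN(C(=O)N3CCN(C)CC3)CC2)ccc1Nc1nc(NC2CCCCC2)c2nc[nH]c2n1` gives 75000 nM, the highest of the three. Placing (4-methylpiperazin-1-yl)carbonyl on the same nitrogen makes a 3.9-fold higher number from compound 1 to compound 3 (0.60 log units; beyond the scatter), while exchanging 4-hydroxycyclohexyl for 4-methylpiperazin-1-yl on the carbonyl carbon makes a 3.9-fold higher number from compound 2 to compound 3 (0.60 log units; beyond the scatter).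

Compound 4 `COc1cc(N2CCN(Cc3ccccn3)CC2)ccc1Nc1nc(NC2CCCCC2)c2nc[nH]c2n1` has (pyridin-2-yl)methyl in place of (4-methylpiperazin-1-yl)carbonyl on an amine nitrogen in a ring. It therefore loses the group that compound 3 alone carries among the measured compounds. For the measured compounds named here, no measured compound carries (pyridin-2-yl)methyl, so its own contribution is unknown. The best guides are the two modest rises into compound 3, read in reverse, together with the absence of change when compound 2 gained a different group on that nitrogen, no change at the digits printed from compound 1 to compound 2 (within the scatter). A modest fall in this assay is thus expected, returning compound 4 to about the level shared by the other two. The estimated change is a 3.8-fold lower number from compound 3 to compound 4 (0.57 log units; beyond the scatter). For compound 4 the expected value is 20000 nM, with an estimated range from 7000 nM to 55000 nM.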

Compound 4, solubility: 38000 nM
For compound 4 the middle estimate is 1.9-fold (0.28 log units) below the measured one; the measured number falls inside the stated range.
By their numbers in this assay, from the lowest: compounds 1, 2, 4 and 3 (each within the scatter of the next, the first and the last beyond it).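

In this assay, all three new steps lie within the scatter: a 2.0-fold lower number from compound 3 to compound 4 (0.30 log units; within the scatter), a 2.0-fold higher number from compound 2 to compound 4 (0.30 log units; within the scatter) and a 2.0-fold higher number from compound 1 to compound 4 (0.30 log units; within the scatter). For the compounds shown here, this shows something the earlier compounds could not: the amine nitrogen in the ring can carry a group joined through a methyl carbon instead of a carbonyl, here (pyridin-2-yl)methyl with its aromatic ring, and the result cannot be told apart from hydrogen, from (4-hydroxycyclohexyl)carbonyl or from (4-methylpiperazin-1-yl)carbonyl. Compound 4 therefore cannot be placed with either side of the one gap beyond the scatter, a 3.9-fold higher number from compound 2 to compound 3 (0.60 log units; beyond the scatter), and no measurement shown here explains its number.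

The compounds shown leave open how a benzyl group, which has a ring carbon where (pyridin-2-yl)methyl has its ring nitrogen, would read in this assay, and so whether that ring nitrogen matters at all. They also leave open whether a (4-methylpiperazin-1-yl)methyl group, which keeps the ring of compound 3 but replaces its carbonyl with a methylene, would stay near compound 3 at 75000 nM or fall towards the other compounds.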